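Working notes: the step from compound 1 to compound 4

A few compounds are considered here, and "the series" means these few. Any claim that something is new, unique, unknown or untested is made for them only; others in the source may bear on it.

In a functional assay on NCI-H460 cells (Homo sapiens) for positive allosteric modulation, read by MTT assay, with stated times of 2 h and 72 h, tested at 1 uM (on this read-out lower numbers stand for stronger inhibition and higher numbers for weaker inhibition), compound 1 (`COc1cccc(-n2nnc(-c3ccccc3NC(=O)c3ccc(NC(C)=O)cc3)n2)c1`) gives 725 nM and compound 2 (`COc1cccc(-n2nnc(-c3ccccc3NC(=O)c3ccc(N=[N+]=[N-])cc3)n2)c1`) gives 558 nM. These two sit together at the high end of the numbers, while compound 3 (`COc1ccc(NC(=O)Nc2ccccc2-c2nnn(-c3ccc(OC)cc3)n2)cc1`) lies lower at 255 nM. Compound 4 (`COc1cccc(-n2nnc(-c3ccccc3NC(=O)Nc3ccc(N)cc3)n2)c1`) differs from compound 1 as follows: (4-aminophenyl)amino in place of 4-acetamidophenyl on a carbonyl carbon. Among the measured compounds shown here, the only measured step, a 1.3-fold lower number from compound 1 to compound 2 (0.11 log units; within the scatter), changes a different place and gives little guidance. Like compound 4, compound 3 has a nitrogen on that carbonyl carbon, and at 255 nM compound 3 suggests a lower number, although its core differs. The expected step is a 1.7-fold lower number from compound 1 to compound 4 (0.24 log units; within the scatter), and this direction remains tentative. For compound 4 the estimated value is 420 nM, with an expected range of 150 nM to 1100 nM.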

Compound 4, half-maximal inhibitory concentration: 228 nM
For compound 4 the middle estimate is 1.8-fold (0.27 log units) above the measured one, and the stated range covers the measured number.
By their numbers in this assay, from the lowest: compounds 4 and 3 (each within the scatter of the next); then compounds 2 and 1 (each within the scatter of the next).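

In this assay, this position on the carbonyl carbon responds beyond the scatter: (4-aminophenyl)amino in place of 4-acetamidophenyl gives a 3.2-fold lower number from compound 1 to compound 4 (0.50 log units; beyond the scatter), a shift the azido for acetamido step did not produce. The same group in place of 4-azidophenyl gives a 2.4-fold lower number from compound 2 to compound 4 (0.39 log units; beyond the scatter), so the lower number holds against both compounds sharing the core. No measurement available here accounts for either step. The change alters two features at once, leaving the contribution of the nitrogen on the carbonyl carbon unseparated from that of the ring amino group. Going by these compounds, how a carboxylic acid or a dimethylamino group on that ring would compare remains open.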